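The source may report more compounds than this note shows. Statements on the series, on what has been measured and on what is new or still open speak of the compounds shown alone.

Three compounds share one core and were tested in an ADME assay on Vero cells (Chlorocebus sabaeus) for cytotoxicity, read by neutral red uptake, tested at 394 ug/mL; on this read-out lower numbers stand for a stronger effect and higher numbers for a weaker effect at the one concentration tested. Compound 1 `O=C1CSC(c2cccc(Cl)c2)N1CCN1CCCCC1` gives 45%; compound 2 `O=C1CSC(c2cccc(O)c2)N1CCN1CCCCC1` gives 100%; compound 3 `O=C1CSC(c2ccc(O)cc2)N1CCN1CCCCC1` gives 76%. Compound 3 thus holds the second highest of the three numbers, with a number 24 percentage points lower from compound 2 to compound 3 (beyond the scatter) and a number 31 percentage points higher from compound 1 to compound 3 (beyond the scatter). Compound 4 `O=C1CSC(c2ccc(F)cc2)N1CCN1CCCCC1` differs from compound 3 by fluoro in place of hydroxy on an aromatic carbon. For the measured compounds named here, two steps bear on this change: a number 55 percentage points higher from compound 1 to compound 2 (beyond the scatter) and a number 31 percentage points higher from compound 1 to compound 3 (beyond the scatter), both of which ran from a halogen to a hydroxy group and lifted the number strongly. Since the present change runs the opposite way, the number is expected to fall beyond the scatter, by about a number 26 percentage points lower from compound 3 to compound 4 (beyond the scatter). Compound 4 is therefore estimated at 50%, expected to lie between 25% and 80%.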

Compound 4, a percentage reported as activity, at one concentration (the size of the read-out at that concentration, not a potency): 52%
For compound 4 the middle estimate is 2 percentage points below the measured one; the range from low to high includes it.
By their numbers in this assay, from the lowest: compounds 1 and 4 (each within the scatter of the next); then compound 3; then compound 2.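

In this assay, fluoro and hydroxy are now compared directly at the place para to a large group, and this single swap gives a number 24 percentage points lower from compound 3 to compound 4 (beyond the scatter). The wider change gives a number 48 percentage points lower from compound 2 to compound 4 (beyond the scatter), but it alters both the group and its place. The step of a number 7 percentage points higher from compound 1 to compound 4 (within the scatter) means that 4-fluorophenyl and 3-chlorophenyl cannot be told apart here.

As far as these compounds go, whether an amine or a methoxy group at this place would read closer to hydroxy or to fluoro remains open. Nothing available explains the gap between hydroxy and fluoro.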